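The compounds below may be only part of what the source reports. "The series", "measured", "known", "first", "only" and "open" are said of these compounds alone.

Measured compounds:
compound 1, `O=C(/C(=C\c1c(-c2ccccc2)[nH]c2ccccc12)S(=O)(=O)c1ccccc1)c1ccccc1`, 9900 nM in a functional assay on SR cells (Homo sapiens) for inhibition, read by sulforhodamine B assay, with a stated time of 48 h; a lower number here means a stronger inhibitor of growth, a higher number a weaker inhibitor of growth
compound 2, `COc1ccc2[nH]c(-c3ccccc3)c(/C=C(\C#N)S(=O)(=O)c3ccccc3)c2c1`, 2200 nM in this assay

Among the measured compounds shown here, compound 2 stands at the lower of the two numbers measured so far; compound 1 gives the higher number, and the gap between them lies beyond the usual scatter. Compound 3, `N#C/C(=C\c1c(-c2ccccc2)[nH]c2ccccc12)S(=O)(=O)c1ccccc1`, has not yet been measured. It differs from compound 2 in one place: hydrogen in place of methoxy on an aromatic carbon. No step of this exact kind, with the rest of the molecule held fixed, has been measured, so the expected size of the step rests on general experience rather than on a shown comparison. A change this small on the fused core is expected to move the number little, if at all beyond the scatter, with a mild drift towards a higher number held as the more likely direction. The estimate for compound 3 in this assay is therefore 3500 nM, within a range from 1200 nM to 10000 nM, which corresponds to an expected step of a 1.6-fold higher number from compound 2 to compound 3 (0.20 log units; within the scatter).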

Compound 3, concentration for 50% growth inhibition: 17300 nM
For compound 3 the middle estimate is 4.9-fold (0.69 log units) below the measured one; the whole stated range lies below it.
By their numbers in this assay, from the lowest: compound 2; then compounds 1 and 3 (each within the scatter of the next).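

In this assay, hydrogen in place of methoxy on the aromatic carbon gives a 7.9-fold higher number from compound 2 to compound 3 (0.90 log units; beyond the scatter) and this lies beyond the scatter, which shows that the group at this place, meta to a fused ring and para to a fused ring, matters in this small set. Cyano in place of benzoyl on the double-bonded chain carbon gives a 1.7-fold higher number from compound 1 to compound 3 (0.24 log units; within the scatter) and this stays within the scatter, so compound 1 and compound 3 cannot be told apart in this measurement. The data offered give no reason for the size of the methoxy step.

On these data alone, whether a hydroxyl, an ethoxy or an amine at the same aromatic carbon would match methoxy remains open. As far as these compounds go, it is also open whether the methoxy step would keep its size with benzoyl on the chain in place of cyano.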